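This account rests on a few compounds, and the source may have more. Where it says the series, first, only, none or still open, it means among the compounds named here.

The study covers three measured compounds and one awaiting measurement. Compound 1 `COc1cccc(Oc2ccc3c(NCCCNCc4cc(F)ccc4OC)ccnc3c2)c1` gives 7100 nM in an ADME assay on HepG2 cells (Homo sapiens) for cytotoxicity, read by luminescence, CellTiter-Glo and ATP content, with a stated time of 72 h; on this read-out higher numbers stand for an effect only at larger amounts of compound and lower numbers for an effect already at smaller amounts. Compound 2 `Fc1ccc(Cc2ccc3c(NCCCNCc4ccco4)ccnc3c2)cc1` gives 5600 nM in this assay, and compound 3 `COc1cccc(CNCCCNc2ccnc3cc(Cc4ccc(F)cc4)ccc23)c1O` gives 4780 nM. Compound 2 stands second highest of the three numbers; its nearest neighbour is compound 3 and its furthest is compound 1, and both gaps lie within the scatter. Among the measured compounds shown here, the only measured step, a 1.2-fold lower number from compound 2 to compound 3 (0.07 log units; within the scatter), concerns a saturated chain carbon bound to an amine nitrogen and stays within the scatter.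

Compound 4 `c1ccc(-c2ccc3c(NCCCNCc4ccco4)ccnc3c2)cc1` differs from compound 2 as follows: phenyl in place of 4-fluorobenzyl on an aromatic carbon. For the measured compounds named here, no measured step touches the aromatic carbon of the fused system where this change sits, so nothing measured bears on it directly, and the single step available lies elsewhere and within the scatter. Since all three measured values sit within the scatter of one another, the expectation is for no step beyond the scatter, namely a 1.0-fold lower number from compound 2 to compound 4 (0.01 log units; within the scatter). Compound 4 is therefore estimated at 5500 nM, with a range from 2500 nM to 12000 nM.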

Compound 4, half-maximal effective concentration: 5920 nM
Compound 4: the middle estimate sits 1.1-fold (0.03 log units) below what was measured, within the range that was stated.
By their numbers in this assay, from the lowest: compounds 3, 2, 4 and 1 (each within the scatter of the next).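

Among the compounds shown here, at this aromatic carbon of the shared core, a position no earlier step had touched, this assay gives a 1.1-fold higher number from compound 2 to compound 4 (0.02 log units; within the scatter) for phenyl in place of 4-fluorobenzyl. The exchange takes the group from 8 heavy atoms to 6 and removes the fluorine, while the six-membered aromatic ring of carbon only stays, and the reading still remains within the scatter. Nothing at hand gives a measured reason for this result or shows what it depends on.

The compounds shown leave open how a plain benzyl group would read here, or a group of another kind on this aromatic carbon, such as an amine or a carboxylic acid. They also leave open whether the same exchange would read alike with the 2-hydroxy-3-methoxyphenyl group of compound 3 in place of furan-2-yl.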